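The source may hold more compounds than are shown below. What is called first, only, known or untested is meant among the compounds shown, and "the series" means these compounds.

Measured so far:
compound 1 `COc1ccc(CNC(=O)/C=C/c2coc3cc(O)ccc3c2=O)cc1` — > 100000 nM, a limit of the assay
compound 2 `COc1ccc2c(=O)c(/C=C/C(=O)Nc3ccccc3Cl)coc2c1` — 22400 nM
compound 3 `COc1ccc(NC(=O)/C=C/c2coc3cc(O)ccc3c2=O)cc1` — > 100000 nM, a limit of the assay

Among the compounds with values here, in a functional assay on HeLa cells (Homo sapiens) for inhibition, read by MTT assay, with a stated time of 48 h (on this read-out lower numbers stand for stronger inhibition and higher numbers for weaker inhibition), compound 2 gives 22400 nM, the only actual number in the set. Compound 1 reaches only the limit > 100000 nM in this assay. Compound 3 likewise stops at the limit > 100000 nM. Within the data shown here, compound 2 therefore stands alone as the one measured value, with the limit of > 100000 nM in this assay, at which 2 of the 3 values shown sit, holding the other two. Compound 4 `COc1ccc2c(=O)c(/C=C/C(=O)Nc3ccc(Cl)cc3)coc2c1` is not yet measured; it differs from compound 2 by 4-chlorophenyl in place of 2-chlorophenyl on an amide-type nitrogen. Among the measured compounds shown here, no measured pair shows this change, so its size is unknown; a step within the usual scatter, or a small one in either direction, is expected in this assay. Compound 4 is estimated at 20000 nM, within 7000 nM to 60000 nM, an expected step of a 1.1-fold lower number from compound 2 to compound 4 (0.05 log units; within the scatter).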

Compound 4, half-maximal inhibitory concentration: > 100000 nM
Compound 4 ended at the assay's limit; the forecaster's own chance of this, stated with the estimate: 15%; middle value at least 5.0-fold (0.69 log units) away from the limit.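

In this assay, 4-chlorophenyl in place of 2-chlorophenyl on an amide-type nitrogen gives an at least 4.4-fold higher number from compound 2 to compound 4 (0.64 log units; beyond the scatter), so with the same atoms joined differently, this place in the series is sensitive to the change. On these data alone, compound 4 gives > 100000 nM, which is a limit and not a number, so the true size of the step stays unknown. Compound 2 remains the only measured number, with the rest of the set at one ceiling: the limit of > 100000 nM in this assay, at which 3 of the 4 values shown sit.

Still open, as far as these compounds go, is whether the chlorine itself is needed. From the compounds shown here alone, whether a measurable value survives with 2-methylphenyl or unsubstituted phenyl on that nitrogen remains unknown.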